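Replacing tert-butyl with pyridin-2-yl on the side chain

A few compounds are considered here, and "the series" means these few. Any claim that something is new, unique, unknown or untested is made for them only; others in the source may bear on it.

Three compounds have been measured so far in an ADME assay on liver for metabolic stability, with Liver microsome (Homo sapiens) as the target, read by LC-MS, using microsomes (a higher number here means faster removal of the compound, a lower number slower removal), as follows
- compound 1 `O=C(NCc1cc(Cl)ccc1-n1cnnn1)[C@@H]1C[C@@H]2C[C@@H]2N1C(=O)[C@H](O)Cn1cccn1` gives < 12 mL.min-1.g-1 as a limit of the assay, not a number
- compound 2 `CC(C)(C)[C@@H](O)C(=O)N1[C@H](C(=O)NCc2cc(Cl)ccc2-n2cnnn2)C[C@@H]2C[C@@H]21` gives 75 mL.min-1.g-1 as a number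
- compound 3 `CC(C)(C)C[C@@H](O)C(=O)N1[C@H](C(=O)NCc2cc(Cl)ccc2-n2cnnn2)C[C@@H]2C[C@@H]21` gives 40 mL.min-1.g-1 as a number

Two of these numbers sit together, and the gap of a 1.9-fold lower number from compound 2 to compound 3 (0.27 log units; within the scatter) gives them no order. Compound 3 therefore shares the upper end of the measured numbers.

The next compound is compound 4 `O=C(NCc1cc(Cl)ccc1-n1cnnn1)[C@@H]1C[C@@H]2C[C@@H]2N1C(=O)[C@H](O)Cc1ccccn1` and the change is pyridin-2-yl in place of tert-butyl on a saturated chain carbon, two bonds along the chain from a carbonyl carbon and an oxygen on a saturated carbon with pyridin-2-yl in place of tert-butyl on a saturated chain carbon, two bonds along the chain from a carbonyl carbon and an oxygen on a saturated carbon. The closest measured change is an at least 3.3-fold higher number from compound 1 to compound 3 (0.52 log units; beyond the scatter) with tert-butyl replacing 1H-pyrazol-1-yl at that same place. A related change is an at least 6.2-fold higher number from compound 1 to compound 2 (0.79 log units; beyond the scatter) with tert-butyl replacing (1H-pyrazol-1-yl)methyl. Read backwards, with a ring returning at that place, these steps point to a lower number, although no measured compound carries pyridin-2-yl. The estimated step in this assay is a 2.5-fold lower number from compound 3 to compound 4 (0.40 log units; beyond the scatter) and so a fall is expected. For compound 4 the estimate is 16 mL.min-1.g-1 with an expected range from 8 mL.min-1.g-1 to 32 mL.min-1.g-1 as its limits.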

Compound 4, intrinsic clearance in microsomes: 17 mL.min-1.g-1
The estimate for compound 4 lay 1.1-fold (0.03 log units) below the measured number, within the range that was stated.
By their numbers in this assay, from the lowest: compound 4; then compounds 3 and 2 (each within the scatter of the next). At a limit, below all of these: compound 1.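

In this assay, the 1H-pyrazol-1-yl group of compound 1 was the only ring yet seen on this side chain, and pyridin-2-yl now shows that a second, six-membered aromatic ring also goes with a lower number than the alkyl groups, with a 2.4-fold lower number from compound 3 to compound 4 (0.37 log units; beyond the scatter) and a 4.4-fold lower number from compound 2 to compound 4 (0.64 log units; beyond the scatter). Against the pyrazole compound the step is an at least 1.4-fold higher number from compound 1 to compound 4 (0.15 log units; that floor lies within the scatter), so these two rings cannot be put in order. As far as these compounds go, compound 1 carries a limit of the assay, not a number, and the true gap between the two rings stays unknown because of it: the limit of < 12 mL.min-1.g-1 in this assay, at which 1 of the 4 values shown sits.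

From the compounds shown here alone, whether the ring nitrogen matters remains open, and phenyl at this place would separate the ring from that nitrogen. Going by these compounds, how an amine or a carboxylic acid on the same chain would behave is also open.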